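Changing the Ester: Butyl Replaced by Trifluoromethoxyphenyl

The source may report more compounds than this note shows. Statements on the series, on what has been measured and on what is new or still open speak of the compounds shown alone.

Compound 1, `COc1cc2c(c(O)c1C(=O)/C=C/c1ccc(OC(=O)c3ccc(Cl)nc3)cc1)CCC(C)(C)O2`: in an assay on HEK293T cells for inhibition of nuclear factor NF-kappa-B complex (Homo sapiens), read by a luciferase reporter (a lower number here means a stronger inhibitor, a higher number a weaker inhibitor), compound 1 gives > 30000 nM, a limit.
Compound 2, `CCCCC(=O)Oc1ccc(/C=C/C(=O)c2c(OC)cc3c(c2O)CCC(C)(C)O3)cc1`: in this assay compound 2 gives > 30000 nM, also a limit.

Compound 2 therefore stands only at a bound of this assay, with no number behind it. Among the compounds with values here, the single measured step, a step that the two limits leave unreadable from compound 1 to compound 2, cannot be read, because the limit of > 30000 nM in this assay, at which 2 of the 2 values shown sit, holds both values. Compound 3, `COc1cc2c(c(O)c1C(=O)/C=C/c1ccc(OC(=O)c3ccc(OC(F)(F)F)cc3)cc1)CCC(C)(C)O2`, differs from compound 2 by 4-(trifluoromethoxy)phenyl in place of butyl on a carbonyl carbon, so it carries an aromatic ester again, as compound 1 did. With nothing measured pointing elsewhere, compound 3 is expected to sit at 40000 nM, within 15000 nM to 120000 nM, most probably as a limit once more. The expected step that the limit leaves unreadable from compound 2 to compound 3 is thus no change beyond the scatter.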

Compound 3, half-maximal inhibitory concentration: > 30000 nM
Compound 3: a limit, no number (the forecaster's own chance of this, stated with the estimate: 80%); the middle value does not contradict the limit.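

No step between compound 1, compound 2 and compound 3 can be read, because all three values are the same limit, not numbers: the limit of > 30000 nM in this assay, at which 3 of the 3 values shown sit.

The compounds shown leave open whether changing the group on this ester carbonyl alters inhibition in this assay at all.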